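The compounds below may be only part of what the source reports. "The series", "measured", "known", "first", "only" and "open" are said of these compounds alone.

Two compounds of this series have been run in a functional assay on OVCAR-3 cells (Homo sapiens) for inhibition, read by sulforhodamine B assay, with a stated time of 48 h; a higher number here means a weaker inhibitor of growth, a lower number a stronger inhibitor of growth. Compound 1 `CCOC(=O)C1=C(C)NC(=S)NC1c1ccc(O)c(O)c1` gives 25 ug/mL; compound 2 `CCOC(=O)C1=C(C)NC(=O)NC1c1ccc(O)c(O)c1` gives 1.6 ug/mL, the lower of the two numbers, and its gap to compound 1 lies beyond the usual scatter. Compound 3 `CCOC(=O)C1=C(C)NC(=O)NC1c1ccc(O)cc1` has not been measured yet. Its difference from compound 2 is hydrogen in place of hydroxy on an aromatic carbon. Among the compounds with values here, no measured pair shows a matching step, so the direction rests on the change alone; a modest rise in the number, toward weaker growth inhibition, is expected, though none beyond the scatter is also possible. The expected step is a 3.1-fold higher number from compound 2 to compound 3 (0.49 log units; beyond the scatter). Compound 3 is estimated to give about 5 ug/mL in this assay, within 1.5 ug/mL to 20 ug/mL.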

Compound 3, concentration for 50% growth inhibition: 27.3 ug/mL
Compound 3: the middle estimate sits 5.5-fold (0.74 log units) below what was measured; the whole stated range lies below it.
By their numbers in this assay, from the lowest: compound 2; then compounds 1 and 3 (each within the scatter of the next).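

Replacing hydroxy with hydrogen on the aromatic carbon ortho to a hydroxy group and meta to a large group gives a 17-fold higher number from compound 2 to compound 3 (1.23 log units; beyond the scatter) in this assay. In this pair, growth inhibition therefore depends strongly on keeping the hydroxy group at this position. No available evidence explains the size of this step.

Whether another group could stand in for hydroxy here remains open, as a methoxy group, fluorine or an amine at this carbon is not among the compounds shown. From the compounds shown here alone, the contribution of the remaining hydroxy group also remains open.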